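Trifluoromethyl for fluoro on the benzyl of compound 2

The compounds below may be only part of what the source reports. "The series", "measured", "known", "first", "only" and "open" are said of these compounds alone.

In a functional assay on HeLa cells (Homo sapiens) for antiproliferative activity, read by sulforhodamine B assay, with a stated time of 48 h (a higher number here means a weaker inhibitor of growth, a lower number a stronger inhibitor of growth), compound 2 `COc1ccc(-c2nn(-c3ccccc3)cc2C(=O)NCc2cn(Cc3ccc(F)cc3)nn2)cc1` gives 500 nM, the lowest of the two numbers in hand. Going by the values given here, compound 1 `O=C(NCc1cn(Cc2ccc(C(F)(F)F)cc2)nn1)c1cn(-c2ccccc2)nc1-c1ccccc1` gives 1600 nM in this assay, a gap beyond the scatter, but the two structures differ in more than one place, so no single step is isolated from them. Compound 3 `COc1ccc(-c2nn(-c3ccccc3)cc2C(=O)NCc2cn(Cc3ccc(C(F)(F)F)cc3)nn2)cc1` carries the change (trifluoromethyl in place of fluoro on an aromatic carbon). Among the compounds with values here, with no comparable measured step, the move from compound 2 to compound 3 is expected to be small, if anything toward a higher number: a 1.6-fold higher number from compound 2 to compound 3 (0.20 log units; within the scatter). Compound 3 is expected to give 800 nM, within 300 nM to 2500 nM.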

Compound 3, concentration for 50% growth inhibition: 6200 nM
The estimate for compound 3 lay 7.8-fold (0.89 log units) below the measured number; measured number outside the range, above it.
By their numbers in this assay, from the lowest: compound 2; then compound 1; then compound 3.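

In this assay the change from 4-fluorobenzyl to 4-(trifluoromethyl)benzyl is far from neutral, with a 12-fold higher number from compound 2 to compound 3 (1.09 log units; beyond the scatter) at this position. With trifluoromethyl held on the benzyl, methoxy in place of hydrogen on an aromatic carbon gives a 3.9-fold higher number from compound 1 to compound 3 (0.59 log units; beyond the scatter) and so brings no gain in this setting. Nothing at hand explains either step. Still open, as far as these compounds go, is how an unsubstituted benzyl or a 4-chlorobenzyl would sit relative to compound 2. Also open, from the compounds shown here alone, is what methoxy in place of hydrogen does when fluoro, not trifluoromethyl, is on the benzyl.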